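Urea to amide on a pyrazole series tested in melanoma cells

This account rests on a few compounds, and the source may have more. Where it says the series, first, only, none or still open, it means among the compounds named here.

Two analogues of a shared core have been measured in a functional assay on UACC-62 cells (Homo sapiens) for inhibition, read by sulforhodamine B assay, with a stated time of 48 h, tested at 10 uM; on this read-out higher numbers stand for a weaker effect at the one concentration tested and lower numbers for a stronger effect. Compound 1 `COc1cc(Cl)cc(-c2nn(-c3cccc(NC(=O)Nc4ccc(Cl)c(C(F)(F)F)c4)c3)cc2-c2ccncc2)c1` gives 6.62% in this assay, while compound 2 `COc1cc(Cl)cc(-c2nn(-c3cccc(NC(=O)Nc4cccc(C(F)(F)F)c4)c3)cc2-c2ccncc2)c1` gives -11.5%. For the measured compounds named here, the single step between them, a number 18.1 percentage points lower from compound 1 to compound 2 (beyond the scatter), places compound 2 as the lower of the two numbers, and its nearest neighbour is compound 1, a number higher by a step beyond the scatter.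

Compound 3 `COc1cc(Cl)cc(-c2nn(-c3cccc(NC(=O)c4cccc(C(F)(F)F)c4)c3)cc2-c2ccncc2)c1` is not yet measured. It differs from compound 2 by 3-(trifluoromethyl)phenyl in place of (3-(trifluoromethyl)phenyl)amino on a carbonyl carbon. Going by the values given here, no measured step concerns this place on the carbonyl carbon; the only step on record, the exchange of chloro for hydrogen on an aromatic carbon, lies elsewhere in the molecule and cannot be carried over. With nothing to argue for a shift in either direction, compound 3 is expected to land close to compound 2, the step of a number 6.5 percentage points higher from compound 2 to compound 3 (within the scatter) estimated to stay within the usual scatter. Compound 3 is therefore estimated at -5% in this assay, within a range from -30% to 20%.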

Compound 3, a percentage reported as activity, at one concentration (the size of the read-out at that concentration, not a potency): 74.5%
For compound 3 the middle estimate is 79.5 percentage points below the measured one; measured number above the stated range.
By their numbers in this assay, from the lowest: compound 2; then compound 1; then compound 3.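

In this assay, putting 3-(trifluoromethyl)phenyl in place of (3-(trifluoromethyl)phenyl)amino on the carbonyl carbon gives a number 86 percentage points higher from compound 2 to compound 3 (beyond the scatter) and shows that this position, which the earlier chloro-to-hydrogen step did not touch, can change the read-out far more than that step did. The change from the chlorinated urea gives a number 67.9 percentage points higher from compound 1 to compound 3 (beyond the scatter) and runs the same way, though it also removes the chloro, so in both listed pairs the loss of the amino nitrogen and its hydrogen-bond donor goes with a much weaker effect at the one concentration tested. Nothing available here explains why this exchange has so large an effect.

The compounds shown leave open whether the nitrogen itself matters or only the link it forms, which a methylene group or an ether oxygen at this place on the carbonyl carbon could help separate. They also leave open whether a chloro group on the aromatic ring of the amide would shift the number as it does between the two ureas.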